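The source may hold more compounds than are shown below. What is called first, only, known or untested is meant among the compounds shown, and "the series" means these compounds.

Compound 1 `CCNc1ccc(NC(=O)c2cc(Cl)ccc2O)c(Cl)c1` gives 30200 nM in an ADME assay on A549 cells (Homo sapiens) for cytotoxicity, read by resazurin assay, with a stated time of 48 h; on this read-out lower numbers stand for higher toxicity in this test and higher numbers for lower toxicity in this test.
Compound 2 `CC1(Nc2ccc(NC(=O)c3cc(Cl)ccc3O)c(Cl)c2)CCCC1` gives 157000 nM in this assay.

Compound 2 stands highest of the two numbers in this assay; its nearest neighbour is compound 1, a step of a 5.2-fold higher number from compound 1 to compound 2 (0.72 log units; beyond the scatter). Compound 3 `CCN(CC)c1ccc(NC(=O)c2cc(Cl)ccc2O)c(Cl)c1` differs from compound 2 by diethylamino in place of (1-methylcyclopentyl)amino on an aromatic carbon. Among the measured compounds shown here, the only step that bears on this change is the one from compound 1 to compound 2, where a larger group on that nitrogen raised the number modestly. Removing the ring again is therefore expected to lower the number in this assay, roughly back toward compound 1, giving an estimated step of a 3.1-fold lower number from compound 2 to compound 3 (0.50 log units; beyond the scatter). Compound 3 is thus expected to give 50000 nM, within 15000 nM to 160000 nM.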

Compound 3, half-maximal cytotoxic concentration: 55500 nM
The estimate for compound 3 lay 1.1-fold (0.05 log units) below the measured number; the measured number falls inside the stated range.
By their numbers in this assay, from the lowest: compounds 1 and 3 (each within the scatter of the next); then compound 2.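

In this assay, the step of a 2.8-fold lower number from compound 2 to compound 3 (0.45 log units; beyond the scatter) shows that a larger substituent on this nitrogen does not by itself bring the number of compound 2. Adding a second ethyl group gives a 1.8-fold higher number from compound 1 to compound 3 (0.26 log units; within the scatter), so diethylamino and the ethylamino group of compound 1 cannot be told apart here, and only the (1-methylcyclopentyl)amino group stands clear of the others. No measurement given here explains this difference.

As far as these compounds go, since the change from compound 2 to compound 3 removes both the ring and the hydrogen-bond donor, their separate contributions remain open. From the compounds shown here alone, how a cyclopentylamino group or a longer chain on the nitrogen would read also remains open.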